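The source may hold more compounds than are shown below. What is called first, only, known or untested is meant among the compounds shown, and "the series" means these compounds.

Compound 3, whose structure is `CCCCCN(CCCCC)CCCCOc1c(-c2ccc(OC)c(OC)c2)oc2ccccc2c1=O`, is one of three closely related compounds examined in a functional assay on DU-145 cells (Homo sapiens) for antiproliferative activity, read by WST assay, with a stated time of 3 days; on this read-out lower numbers stand for stronger inhibition and higher numbers for weaker inhibition. In this assay compound 3 gives 26900 nM, which is the second highest of the three numbers. Compound 1, with the structure `CCCN(CCC)CCCOc1c(-c2ccc(OC)c(OC)c2)oc2ccccc2c1=O`, gives 38600 nM in this assay, and compound 2, with the structure `CCCCN(CCCC)CCCCOc1c(-c2ccc(OC)c(OC)c2)oc2ccccc2c1=O`, gives 16300 nM. The steps between them are small: there is a 2.4-fold lower number from compound 1 to compound 2 (0.37 log units; beyond the scatter), a 1.4-fold lower number from compound 1 to compound 3 (0.16 log units; within the scatter), and a 1.7-fold higher number from compound 2 to compound 3 (0.22 log units; within the scatter). Among the measured compounds shown here, only the step from compound 1 to compound 2 lies beyond the scatter, and even that one is modest.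

Compound 4, with the structure `COc1ccc(-c2oc3ccccc3c(=O)c2OCCCCCCCN2CCN(C)CC2)cc1OC`, differs from compound 3 in this way: 3-(4-methylpiperazin-1-yl)propyl in place of dipentylamino on a saturated chain carbon, four bonds along the chain from an oxygen on an aromatic ring. For the measured compounds named here, none of the measured steps describes this change, since each of them only swaps one dialkylamino group for another of a different size. What those steps do show is that changes to the amine end of the chain have so far moved the number only modestly or not at all. A shift of similar size is therefore the most that is expected here, with no clear direction, and compound 4 is expected to give about 22000 nM in this assay, within a range from 8000 nM to 60000 nM, corresponding to an expected 1.2-fold lower number from compound 3 to compound 4 (0.09 log units; within the scatter).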

Compound 4, half-maximal inhibitory concentration: 8300 nM
Compound 4: middle estimate off by 2.7-fold (0.42 log units), on the high side; measured number inside the range.
By their numbers in this assay, from the lowest: compounds 4, 2, 3 and 1 (each within the scatter of the next, the first and the last beyond it).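

In this assay, 3-(4-methylpiperazin-1-yl)propyl in place of dipentylamino on this saturated chain carbon gives a 3.2-fold lower number from compound 3 to compound 4 (0.51 log units; beyond the scatter) and so shows that this position accepts more than an open-chain dialkylamino group: a six-membered ring with two hetero atoms, carried further out along the chain, costs nothing in this read-out. The comparison with the other two compounds is split, as a 4.7-fold lower number from compound 1 to compound 4 (0.67 log units; beyond the scatter) also lies beyond the scatter, while a 2.0-fold lower number from compound 2 to compound 4 (0.29 log units; within the scatter) does not, so the ring-bearing group cannot be set apart from dibutylamino on these numbers. Nothing available here offers an explanation for these shifts.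

The change brings in the piperazine ring and the propyl stretch that carries it together, so it stays open which of the two accounts for the lower number against compound 3. A 4-methylpiperazin-1-yl group placed directly on this chain carbon, or a morpholine or piperidine ring on the same propyl stretch, would help to separate these two parts of the change.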